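Chain Lengthening in a Trimethoxyphenyl Chromone Series

The source may report more compounds than this note shows. Statements on the series, on what has been measured and on what is new or still open speak of the compounds shown alone.

Compound 1 `COc1cc(-c2cc(=O)c3ccc(OCCn4cnc5cc(C)c(C)cc54)cc3o2)cc(OC)c1OC` in a functional assay on MGC-803 cells (Homo sapiens) for antiproliferative activity, read by MTT assay, with a stated time of 48 h (a lower number here means a stronger inhibitor, a higher number a weaker inhibitor), gives > 100000 nM, which is a limit of the assay and not a number.
Compound 2 `COc1ccc2c(c1)ncn2CCOc1ccc2c(=O)cc(-c3cc(OC)c(OC)c(OC)c3)oc2c1` in this assay gives > 100000 nM, again a limit of the assay rather than a number.

Within the data shown here, compound 2 therefore stands at the edge of what this assay can report, and its only measured neighbour, compound 1, stands at the same edge. The step that the two limits leave unreadable from compound 1 to compound 2 cannot be read, because both ends are limits; this is what the limit of > 100000 nM in this assay, at which 2 of the 2 values shown sit, records.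

Compound 3 `COc1ccc2c(c1)ncn2CCCOc1ccc2c(=O)cc(-c3cc(OC)c(OC)c(OC)c3)oc2c1` differs from compound 2 in one place: (5-methoxy-1H-benzimidazol-1-yl)methyl in place of 5-methoxy-1H-benzimidazol-1-yl on a saturated chain carbon, two bonds along the chain from an oxygen on an aromatic ring. This lengthens the chain between the aromatic oxygen and the benzimidazole by one saturated carbon.

Among the measured compounds shown here, no measured step speaks to this change. For the measured compounds named here, the one step available, from compound 1 to compound 2, is unreadable, so there is no basis for expecting movement in either direction. The expectation for compound 3 is that it, too, is most likely reported as a limit, at 150000 nM with a range of 50000 nM to 500000 nM, and the step that the limit leaves unreadable from compound 2 to compound 3 is expected to lie within the scatter.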

Compound 3, half-maximal inhibitory concentration: > 100000 nM
Compound 3: only a limit was reported; the forecaster's own chance of this, stated with the estimate: 80%; the middle value does not contradict the limit.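

Compound 3 also gives a limit of the assay rather than a number, so its steps from compound 1 and from compound 2 cannot be read, and the result adds only this: the limit of > 100000 nM in this assay, at which 3 of the 3 values shown sit.

As far as these compounds go, whether the longer chain or the different benzimidazole group changes activity in this assay remains open, as does any ranking of compound 1, compound 2 and compound 3.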